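Anilide series: single chlorine in place of two

The compounds below may be only part of what the source reports. "The series", "measured", "known", "first", "only" and "open" are said of these compounds alone.

Measured so far:
Compound 1 `Nc1ccccc1NC(=O)CCCNCC(=O)Nc1cc(Cl)ccc1Cl`: 78000 nM in a functional assay on HCT-116 cells (Homo sapiens) for inhibition, read by MTT assay, with a stated time of 2 days; on this read-out lower numbers stand for stronger inhibition of growth and higher numbers for weaker inhibition of growth.
Compound 2 `Cc1ccc(NC(=O)CNc2ccc(C(=O)Nc3ccccc3N)cc2)cc1`: > 100000 nM in this assay, a limit of the assay, not a number.

Compound 1 holds the only number shown in this assay; the other value is the limit of > 100000 nM in this assay, at which 1 of the 2 values shown sits.

Compound 3 `Nc1ccccc1NC(=O)CCCNCC(=O)Nc1ccc(Cl)cc1` differs from compound 1 by 4-chlorophenyl in place of 2,5-dichlorophenyl on an amide-type nitrogen. For the measured compounds named here, no step between two measured compounds is available to calibrate this change. A step from compound 1 to compound 3 in this assay of no more than the usual scatter is expected, in either direction, with the chance that the assay reports only a limit rather than a number being real. The expected step of a 1.3-fold higher number from compound 1 to compound 3 (0.11 log units; within the scatter) is therefore small. For compound 3 a total growth inhibition concentration of 100000 nM is estimated, with a range from 40000 nM to 250000 nM.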

Compound 3, concentration for total growth inhibition: 45000 nM
For compound 3 the middle estimate is 2.2-fold (0.35 log units) above the measured one; the measured number falls inside the stated range.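

This gives the series its first calibrated step on the amide-type nitrogen: in this assay, 4-chlorophenyl in place of 2,5-dichlorophenyl gives a 1.7-fold lower number from compound 1 to compound 3 (0.24 log units; within the scatter) and thus sets no order between the two compounds. The aryl group at this place can therefore lose a chlorine without a change in the read-out beyond the scatter, at least for this one pair, and compound 3 still gives a number. For the compounds shown here, the only limit among the values shown belongs to compound 2, and it is a limit, not a number: the limit of > 100000 nM in this assay, at which 1 of the 3 values shown sits.

This single step alters the number and the placement of chlorine together, and the two cannot be read apart. On these data alone, how an unsubstituted phenyl, a methoxyphenyl or a carboxylic acid on this ring would read remains open, as does a longer chain in the linker.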